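The source may report more compounds than this note shows. Statements on the series, on what has been measured and on what is new or still open speak of the compounds shown alone.

Measured so far:
- Compound 1 `C=C(C)CCOC(=O)C[C@@H]1C(C(=O)OC)=CO[C@@H](O[C@@H]2O[C@H](COC(C)=O)[C@@H](OC(C)=O)[C@H](OC(C)=O)[C@H]2OC(C)=O)/C1=C/C`: > 15000 nM, a limit
- Compound 2 `C/C=C1/[C@H](O[C@@H]2O[C@H](COC(C)=O)[C@@H](OC(C)=O)[C@H](OC(C)=O)[C@H]2OC(C)=O)OC=C(C(=O)OC)[C@H]1CC(=O)OCCC(C)C`: > 15000 nM, a limit
- Compound 3 `C/C=C1/[C@H](O[C@@H]2O[C@H](COC(C)=O)[C@@H](OC(C)=O)[C@H](OC(C)=O)[C@H]2OC(C)=O)OC=C(C(=O)OC)[C@H]1CC(=O)SCCC`: > 15000 nM, a limit

In a functional assay on SK-BR-3 cells (Homo sapiens) for antiproliferative activity, read by MTT assay, with a stated time of 72 h (on this read-out lower numbers stand for stronger inhibition and higher numbers for weaker inhibition), compound 3 gives > 15000 nM, which is a limit and not a number. It has company, as the series shows (the limit of > 15000 nM in this assay, at which 3 of the 3 values shown sit).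

Compound 4 `C/C=C1/[C@H](O[C@@H]2O[C@H](COC(C)=O)[C@@H](OC(C)=O)[C@H](OC(C)=O)[C@H]2OC(C)=O)OC=C(C(=O)OC)[C@H]1CC(=O)OCCC` differs from compound 3 in one place: propoxy in place of propylsulfanyl on a carbonyl carbon. Put simply, this is propoxy in place of propylsulfanyl on a carbonyl carbon.

The closest measured steps are a step that the two limits leave unreadable from compound 2 to compound 3 and a step that the two limits leave unreadable from compound 1 to compound 3, as each also alters what sits on that carbonyl carbon. Neither has a readable size, and the same is true of a step that the two limits leave unreadable from compound 1 to compound 2.

Compound 2 carries isopentyloxy on that carbon and gives > 15000 nM, again a limit. An oxygen-linked chain at this carbon therefore gives no reason to expect a gain, and no step beyond the usual scatter is expected in either direction. The expected outcome is a step that the limit leaves unreadable from compound 3 to compound 4, and the assay will most likely report only a limit again.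

For compound 4 the estimate is 20000 nM, with an expected range from 12000 nM to 40000 nM.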

Compound 4, half-maximal inhibitory concentration: 6600 nM
Beside the measured number, compound 4's estimate is 3.0-fold (0.48 log units) above it; the measured number lies below the stated range.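

In this assay, what sits on this carbonyl carbon can now be seen to matter: propoxy in place of propylsulfanyl gives an at least 2.2-fold lower number from compound 3 to compound 4 (0.35 log units; beyond the scatter). An oxygen link alone does not account for this, since methyl in place of isopropyl on the chain gives an at least 2.2-fold lower number from compound 2 to compound 4 (0.35 log units; beyond the scatter), and methyl in place of 1-methylethenyl gives an at least 2.2-fold lower number from compound 1 to compound 4 (0.35 log units; beyond the scatter), so the rest of the chain counts as well. The steps among compound 1, compound 2 and compound 3 cannot be read, and compound 4 is the only one to leave the limit: the limit of > 15000 nM in this assay, at which 3 of the 4 values shown sit.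

As far as these compounds go, whether ethoxy or butoxy on this carbonyl carbon would lower the number further remains open, so the best chain is not yet known. From the compounds shown here alone, it is also open how an amide made from an amine, or the free carboxylic acid, would compare with the propoxy ester.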